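From Hydroxymethyl to a New Chain End Group

A few compounds are considered here, and "the series" means these few. Any claim that something is new, unique, unknown or untested is made for them only; others in the source may bear on it.

Compound 1 `Cc1cn(/C=C/C=O)c(=O)[nH]c1=O` gives 23000 nM
Compound 2 `CC(=O)/C=C/n1cc(C)c(=O)[nH]c1=O` gives > 100000 nM as a limit
Compound 3 `Cc1cn(/C=C/CO)c(=O)[nH]c1=O` gives > 100000 nM as a limit

These values come from a functional assay on HeLa cells (Homo sapiens) for inhibition (a higher number here means a weaker inhibitor, a lower number a stronger inhibitor), and only compound 1 has an exact number there. Compound 3 sits at the limit of > 100000 nM in this assay, at which 2 of the 3 values shown sit, and has no exact value.

Compound 4 `Cc1cn(/C=C/C=N/O)c(=O)[nH]c1=O` differs from compound 3 by a single swap (a group of 3 heavy atoms (1 carbon, 1 nitrogen, 1 oxygen; no ring) in place of a group of 2 heavy atoms (1 carbon, 1 oxygen; no ring), on a double-bonded chain carbon bound to a double-bonded chain carbon). Hydroxymethyl leaves, and a group with no common name enters, on a double-bonded chain carbon bound to a double-bonded chain carbon.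

Within the data shown here, two measured steps bear on this swap. Hydroxymethyl in place of formyl cost strength (an at least 4.3-fold higher number from compound 1 to compound 3 (0.63 log units; beyond the scatter)), and so did methyl in place of hydrogen on a carbonyl carbon (an at least 4.3-fold higher number from compound 1 to compound 2 (0.63 log units; beyond the scatter)). Both lie beyond the scatter, and both are minimum sizes. The third step (a step that the two limits leave unreadable from compound 2 to compound 3) gives no size.

The entering group carries a double bond, as the formyl of compound 1 does (23000 nM), so a modest gain is expected. Caution remains, since the methyl step kept the carbonyl and still lost strength (an at least 4.3-fold higher number from compound 1 to compound 2 (0.63 log units; beyond the scatter)). The estimated change is small and toward a lower number (an at least 1.4-fold lower number from compound 3 to compound 4 (0.15 log units; that floor lies within the scatter)), and this assay may again report only a limit. For compound 4 the estimated value is 70000 nM with an expected range (20000 nM to 150000 nM).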

Compound 4, half-maximal inhibitory concentration: > 100000 nM
Compound 4: only a limit was reported; the forecaster's own chance of this, stated with the estimate: 55%; at least 1.4-fold (0.15 log units) between middle value and limit.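

The new end group carries a double bond, as the formyl does, yet it does not match the formyl: in this assay the swap gives an at least 4.3-fold higher number from compound 1 to compound 4 (0.63 log units; beyond the scatter). Among the end groups at this place, only the formyl of compound 1 gives an exact value, so a double bond in the end group is not enough on its own to give a measurable effect, as compound 2 and compound 4 both show. The steps from compound 2 to compound 4 and from compound 3 to compound 4 cannot be read, because each of these compounds gives only a limit: the limit of > 100000 nM in this assay, at which 3 of the 4 values shown sit.

Still open, as far as these compounds go, is how far apart compound 2, compound 3 and compound 4 truly lie, since their limits hide any difference among them. Also open, from the compounds shown here alone, is whether any other end group at this place, such as a carboxylic acid, a nitrile or an amine, could give a lower number than compound 1 does at 23000 nM.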